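Series notes: removing the piperidin-1-yl group from compound 3

The source may hold more compounds than are shown below. What is called first, only, known or untested is meant among the compounds shown, and "the series" means these compounds.

Of the compounds shown here, three of the shared core have been measured in a functional assay on Caco-2 cells (Homo sapiens) for inhibition, read by MTT assay, with a stated time of 48 h, tested at 10 uM; on this read-out lower numbers stand for less inhibition of growth and higher numbers for more inhibition of growth at the one concentration tested. Compound 1 `Cc1cc(=O)c2c(O)cc(OCc3ccccc3)c([C@H]3CCN(C)C[C@H]3O)c2o1` gives 18%. Among the measured compounds shown here, compound 2 `Cc1cc(=O)c2c(O)cc(OC/C=C/c3ccccc3)c([C@H]3CCN(C)C[C@H]3O)c2o1` gives 9%; the only completed step, a number 9 percentage points lower from compound 1 to compound 2 (within the scatter), concerns the group on a saturated chain carbon bound to an oxygen on an aromatic ring and is within the scatter. Compound 3 `Cc1cc(=O)c2c(O)c(CN3CCC(N4CCCCC4)CC3)c(O)c([C@H]3CCN(C)C[C@H]3O)c2o1` gives 31%, the highest of the three numbers, with compound 1 nearest and compound 2 furthest, both beyond the scatter below it.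

Compound 4 `Cc1cc(=O)c2c(O)c(CN3CCCCC3)c(O)c([C@H]3CCN(C)C[C@H]3O)c2o1` is not yet measured. It differs from compound 3 in one place: hydrogen in place of piperidin-1-yl on a saturated ring carbon. For the measured compounds named here, no measured step touches this part of the structure, and the step from compound 1 to compound 2 altered a different group, so it offers no guide to size or direction here. The expectation therefore rests on compound 3 alone, with a wide range that allows a move in either direction or none beyond the scatter. The step expected is a number 6 percentage points lower from compound 3 to compound 4 (within the scatter). Compound 4 is estimated at 25%, within 8% to 42%.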

Compound 4, percent growth inhibition at one concentration: 22%
Compound 4: the middle estimate sits 3 percentage points above what was measured; low and high end bracket the measured number.
By their numbers in this assay, from the lowest: compounds 2, 1, 4 and 3 (each within the scatter of the next, the first and the last beyond it).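

In this assay, among the compounds shown here, taking the piperidin-1-yl group off the saturated ring carbon gives a number 9 percentage points lower from compound 3 to compound 4 (within the scatter) and provides the first reading at this position. Loss of this whole six-membered non-aromatic ring, three ring bonds from the ring nitrogen, therefore leaves the number within the scatter, and the piperidin-1-yl group is not shown to be required for the growth inhibition of compound 3 at the one concentration tested. Nothing measured on these compounds accounts for the size or direction of this step.

Going by these compounds, it remains open whether a different group on this ring carbon, such as dimethylamino, hydroxyl or a carboxylic acid, would move the number beyond the scatter. On these data alone, it also remains open whether a morpholine ring in place of the ring carrying this position would do so.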